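A few compounds are considered here, and "the series" means these few. Any claim that something is new, unique, unknown or untested is made for them only; others in the source may bear on it.

Compounds measured in a functional assay on MCF7 cells (Homo sapiens) for cytotoxicity, read by MTT assay, with a stated time of 48 h; on this read-out higher numbers stand for weaker inhibition and lower numbers for stronger inhibition:

- compound 1 `COc1ccc(C(=O)C2Sc3nnc(-c4cc(OC)c(OC)c(OC)c4)n3NC2c2ccco2)cc1` — > 100000 nM
- compound 2 `COc1cc(-c2nnc3n2NC(c2ccco2)C(C(=O)c2ccc(Br)cc2)S3)cc(OC)c1OC` — > 100000 nM
- compound 3 `COc1cc(-c2nnc3n2NC(c2ccco2)C(C(=O)c2cccc4ccccc24)S3)cc(OC)c1OC` — > 100000 nM

Compound 1 stands at a limit of this assay, not at a number, and that is all its value tells. Compound 2 sits at the same kind of limit. Compound 3 sits at a limit as well, so all three measured values share (the limit of > 100000 nM in this assay, at which 3 of the 3 values shown sit). The change from compound 1 to compound 4 `COc1cc(-c2nnc3n2NC(c2ccco2)C(C(=O)c2ccc([N+](=O)[O-])cc2)S3)cc(OC)c1OC` is nitro in place of methoxy on an aromatic carbon, a swap at the same place on the same ring as the step from compound 1 to compound 2, which was a step that the two limits leave unreadable from compound 1 to compound 2. The other measured steps, a step that the two limits leave unreadable from compound 1 to compound 3 and a step that the two limits leave unreadable from compound 2 to compound 3, are likewise unreadable between limits. Going by the values given here, no measured step therefore gives a size or a direction, and the expectation is that compound 4 again fails to reach a readable value, the estimated step being a step that the limit leaves unreadable from compound 1 to compound 4. Compound 4 is estimated at 150000 nM, with a range from 50000 nM to 500000 nM, most probably reported only as a limit.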

Compound 4, half-maximal inhibitory concentration: > 100000 nM
Compound 4 ended at the assay's limit (the forecaster's own chance of this, stated with the estimate: 85%); the middle value does not contradict the limit.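

Going by these compounds alone, no step from compound 4 to compound 1, compound 2 or compound 3 can be read in this assay, since all four compounds share one limit: the limit of > 100000 nM in this assay, at which 4 of the 4 values shown sit. The compounds shown leave open how these four compare with one another in this assay.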